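The source may report more compounds than this note shows. Statements on the series, on what has been measured and on what is new or still open speak of the compounds shown alone.

Of the compounds shown here, three have so far been tested in a functional assay on 786-0 cells (Homo sapiens) for inhibition, read by sulforhodamine B assay, with a stated time of 48 h; on this read-out lower numbers stand for stronger inhibition of growth and higher numbers for weaker inhibition of growth. Compound 1 `O=C1C=COC(/C=C/c2ccccc2)C1` gives 138 uM in this assay. Compound 2 `COc1ccc(/C=C/C2CC(=O)C=CO2)cc1` differs from it in one place, (methoxy in place of hydrogen on an aromatic carbon), and gives 192 uM in this assay; the step of a 1.4-fold higher number from compound 1 to compound 2 (0.14 log units; within the scatter) is therefore a small one. Compound 3 `COc1ccc(/C=C/c2cc(=O)cco2)cc1` rests on a different core, and the difference between the two cores is not broken down here. In this assay compound 3 gives 377 uM.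

Compound 4 `COc1ccc(/C=C/c2cc(=O)cco2)cc1OC` has not yet been measured. It differs from compound 3 by methoxy in place of hydrogen on an aromatic carbon. Among the measured compounds shown here, this is the same kind of change as the one from compound 1 to compound 2, but not the same: there the entering methoxy sits para to a group of 9 heavy atoms, whereas here it sits ortho to a methoxy group and meta to a group of 9 heavy atoms. The expected step is a 1.2-fold higher number from compound 3 to compound 4 (0.08 log units; within the scatter), a size that rests on the earlier step of a 1.4-fold higher number from compound 1 to compound 2 (0.14 log units; within the scatter) having stayed within the scatter. Compound 4 is accordingly estimated at 450 uM in this assay, with a likely range from 200 uM to 900 uM.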

Compound 4, concentration for growth inhibition (reported as GI): 635 uM
Beside the measured number, compound 4's estimate is 1.4-fold (0.15 log units) below it; the range from low to high includes it.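

In this assay, the methoxy group that enters gives a 1.7-fold higher number from compound 3 to compound 4 (0.23 log units; within the scatter), a step small enough to be lost in the ordinary spread of repeat measurements. Set beside the earlier step, the same change shows no detectable difference between the two cores: the same change on two cores in this assay, a 1.4-fold higher number (0.14 log units; within the scatter) from compound 1 to compound 2 and a 1.7-fold higher number (0.23 log units; within the scatter) from compound 3 to compound 4, 1.2-fold (0.08 log units) apart, within the scatter of two such steps. This agreement does not make a rule, since it rests on just two pairs, neither step can be told apart from no effect at all, and the entering methoxy does not sit in the same place in the two pairs, so it shows only that nothing here speaks against carrying the change across.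

On these data alone, the aromatic ring in these compounds carries only hydrogen or methoxy, so it remains open whether an amine or a carboxylic acid there would move the number by more than the scatter. Also open, as far as these compounds go, is what a second methoxy, ortho to the first, would do on the core of compound 2.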